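Weakly Cytotoxic Chromone Amides: Swapping the Amide Substituent

This account rests on a few compounds, and the source may have more. Where it says the series, first, only, none or still open, it means among the compounds named here.

Of the compounds shown here, two have been tested in a functional assay on A549 cells (Homo sapiens) for inhibition, read by MTT assay, with a stated time of 48 h; on this read-out lower numbers stand for stronger inhibition and higher numbers for weaker inhibition. Compound 1 `COc1ccc2c(=O)c(/C=C/C(=O)Nc3cc(C)ccc3C)coc2c1` gives 15500 nM. Compound 2 `Cc1ccc(CNC(=O)/C=C/c2coc3cc(O)ccc3c2=O)cc1` gives 17400 nM. Compound 1 has the lower of the two numbers, but the gap to compound 2 lies within the scatter of repeated measurements, so the two cannot be told apart on potency.

Compound 3 `COc1ccc2c(=O)c(/C=C/C(=O)NCc3ccc(F)cc3F)coc2c1` has not been measured yet. It differs from compound 1 in a single place: 2,4-difluorobenzyl in place of 2,5-dimethylphenyl on an amide-type nitrogen. Both compounds 1 and 2 sit in the same weak range despite carrying different amide substituents, so a similar step is expected here: the change from compound 1 to compound 3 is expected to be a 1.0-fold higher number from compound 1 to compound 3 (0.01 log units; within the scatter), no further than the scatter in either direction. Compound 3 is thus expected to give about 16000 nM in this assay, most likely between 6000 nM and 45000 nM.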

Compound 3, half-maximal inhibitory concentration: 13300 nM
Compound 3: the middle estimate sits 1.2-fold (0.08 log units) above what was measured; the measured number falls inside the stated range.
By their numbers in this assay, from the lowest: compounds 3, 1 and 2 (each within the scatter of the next).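

With the shared core held fixed, 2,4-difluorobenzyl in place of 2,5-dimethylphenyl on an amide-type nitrogen gives a 1.2-fold lower number from compound 1 to compound 3 (0.07 log units; within the scatter) in this assay. For the compounds shown here, the earlier pair offered no such single-place step, so this is the first direct sign that this position accepts a clearly different substituent, one with fluorine instead of only carbon and with a different heavy-atom count, without a change that can be told from the scatter. No accompanying measurement offers an explanation for this result.

Both substituents shown carry a six-membered aromatic ring of carbon only, so it remains open whether the same holds for a group without such a ring, such as an amine or a carboxylic acid. A longer chain on the amide-type nitrogen is equally untested by these compounds, and it could show whether this weak range can be left at all.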